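This account rests on a few compounds, and the source may have more. Where it says the series, first, only, none or still open, it means among the compounds named here.

In a functional assay on HL-60 cells (Homo sapiens) for antiproliferative activity, with a stated time of 24 h (on this read-out lower numbers stand for stronger inhibition and higher numbers for weaker inhibition), compound 3 `NC(=O)c1c(NC(=O)c2ccc(C(F)(F)F)cc2)sc2c1CCN(C(=S)Nc1ccccc1Cl)C2` gives 36100 nM, the highest of the two numbers shown. Compound 2 `NC(=O)c1c(NC(=O)c2ccccc2F)sc2c1CCN(C(=O)Nc1ccccc1Cl)C2` gives 32700 nM in this assay, a value within the scatter of that of compound 3. Compound 1 `NC(=O)c1c(NC(=O)c2ccc(C(F)(F)F)cc2)sc2c1CCN(Cc1ccccc1F)C2` reaches only the limit > 50000 nM in this assay (the limit of > 50000 nM in this assay, at which 1 of the 3 values shown sits). On this read-out the change an at least 1.3-fold lower number from compound 1 to compound 3 (0.14 log units; that floor lies within the scatter) therefore sits at the edge of the scatter. Compound 4 `NC(=O)c1c(NC(=O)c2ccc(C(F)(F)F)cc2)sc2c1CCN(C(=O)Nc1ccccc1Cl)C2` differs from compound 3 by a group of 10 heavy atoms (7 carbon, 1 nitrogen, 1 oxygen, 1 chlorine; one six-membered aromatic ring of carbon only) in place of a group of 10 heavy atoms (7 carbon, 1 nitrogen, 1 sulfur, 1 chlorine; one six-membered aromatic ring of carbon only), on an amine nitrogen in a ring. For the measured compounds named here, no measured step covers this exact exchange; the closest guide is that compound 2, which carries the entering group, lies near compound 3. Compound 4 is therefore expected to show a 1.1-fold lower number from compound 3 to compound 4 (0.03 log units; within the scatter), no step beyond the scatter. The estimate for compound 4 is 34000 nM, between 15000 nM and 75000 nM.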

Compound 4, half-maximal inhibitory concentration: > 50000 nM
Compound 4 was reported as a limit (the forecaster's own chance of this, stated with the estimate: 25%); middle value at least 1.4-fold (0.16 log units) from the limit.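

On the amine nitrogen in a ring, (2-chlorophenyl)carbamoyl, which carries oxygen where the group it replaces carries sulfur, gives an at least 1.3-fold higher number from compound 3 to compound 4 (0.14 log units; that floor lies within the scatter) in this assay. On a carbonyl carbon, 4-(trifluoromethyl)phenyl in place of 2-fluorophenyl gives an at least 1.5-fold higher number from compound 2 to compound 4 (0.18 log units; that floor lies within the scatter), so neither exchange is shown to matter beyond the scatter. Compound 4 stands at a limit of the assay, not at a number: the limit of > 50000 nM in this assay, at which 2 of the 4 values shown sit.

The step between compound 1 and compound 4 cannot be read, as both are limits. As far as these compounds go, whether an amine or a longer chain on that ring nitrogen would lower the number stays open.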